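From Cyclohexyl to 5-Chlorofuran-2-yl on the Shared Core

A few compounds are considered here, and "the series" means these few. Any claim that something is new, unique, unknown or untested is made for them only; others in the source may bear on it.

In a functional assay on NCI-H460 cells (Homo sapiens) for cytotoxicity, read by MTT assay, with a stated time of 72 h (on this read-out lower numbers stand for stronger inhibition and higher numbers for weaker inhibition), compound 1 `CC(C)(C)c1[nH]cnc1/C=c1\[nH]c(=O)/c(=C/c2cccc(Oc3ccc(F)cc3)c2)[nH]c1=O` gives 4 nM, and compound 2 `O=c1[nH]/c(=C\c2cccc(Oc3ccc(F)cc3)c2)c(=O)[nH]/c1=C\c1ccccc1` gives 389 nM. For compound 3 `O=c1[nH]/c(=C\C2CCCCC2)c(=O)[nH]/c1=C\c1cccc(Oc2ccc(F)cc2)c1` the reading is > 1000 nM, which is a limit of the assay and not a number. Its standing is the limit of > 1000 nM in this assay, at which 1 of the 3 values shown sits.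

Compound 4 `O=c1[nH]/c(=C\c2ccc(Cl)o2)c(=O)[nH]/c1=C\c1cccc(Oc2ccc(F)cc2)c1` carries 5-chlorofuran-2-yl in place of cyclohexyl on a double-bonded chain carbon bound to an aromatic carbon. Within the data shown here, three measured steps bear on this change. Phenyl in place of 5-(tert-butyl)-1H-imidazol-4-yl gave a 97-fold higher number from compound 1 to compound 2 (1.99 log units; beyond the scatter), and cyclohexyl in its place gave an at least 250-fold higher number from compound 1 to compound 3 (2.39 log units; beyond the scatter). The closest guide is cyclohexyl in place of phenyl, which gave an at least 2.5-fold higher number from compound 2 to compound 3 (0.41 log units; beyond the scatter). Compound 4 again has an aromatic ring at this place but lacks the group of compound 1, so it is expected to land near compound 2 at 389 nM, not near compound 1.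

The expected change is an at least 3.3-fold lower number from compound 3 to compound 4 (0.52 log units; beyond the scatter), toward stronger inhibition in this assay. For compound 4 the estimate is 300 nM, with an expected range of 60 nM to 1200 nM.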

Compound 4, half-maximal inhibitory concentration: 180 nM
Compound 4: the middle estimate sits 1.7-fold (0.22 log units) above what was measured; the range from low to high includes it.
By their numbers in this assay, from the lowest: compound 1; then compound 4; then compound 2. At a limit, above all of these: compound 3.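

In this assay, 5-chlorofuran-2-yl at this place gave an at least 5.5-fold lower number from compound 3 to compound 4 (0.74 log units; beyond the scatter) against cyclohexyl and a 2.2-fold lower number from compound 2 to compound 4 (0.33 log units; beyond the scatter) against phenyl, so among these three groups the order now runs from the furan through phenyl to cyclohexyl. It still falls well short of 5-(tert-butyl)-1H-imidazol-4-yl, with a 45-fold higher number from compound 1 to compound 4 (1.65 log units; beyond the scatter), so a five-membered aromatic ring with a hetero atom does not by itself bring back the number of compound 1. The reading for compound 3 is a limit of the assay and not a number, so its step gives only a bound: the limit of > 1000 nM in this assay, at which 1 of the 4 values shown sits.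

The compounds shown leave open whether the chlorine or the furan ring accounts for the step from phenyl, which a plain furan-2-yl would separate. They also leave open whether the tert-butyl group or the imidazole ring sets compound 1 apart, which a plain 1H-imidazol-4-yl would test.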